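Fluoro to Methylpyridine Swap and Expected Solubility

This account rests on a few compounds, and the source may have more. Where it says the series, first, only, none or still open, it means among the compounds named here.

Compound 1, `Cc1ccc(-c2ccc(CSc3nnc(-c4ccc5c(c4)OCCO5)o3)cc2)cn1` — in a physicochemical assay for solubility, read by HPLC, using the shake flask method (a higher number here means a more soluble compound, a lower number a less soluble compound), compound 1 gives < 1000 nM, which is a limit of the assay.
Compound 2, `Fc1ccc(-c2ccc(CSc3nnc(-c4ccc5c(c4)OCCO5)o3)cc2)cn1` — in this assay compound 2 gives 17000 nM.

For the measured compounds named here, compound 2 holds the only numerical solubility value in this set; the other entry is a limit rather than a number. Going by the values given here, the step of an at least 17-fold higher number from compound 1 to compound 2 (1.23 log units; beyond the scatter) is the one measured comparison, and it bears directly on the next change: the limit in the limit of < 1000 nM in this assay, at which 1 of the 2 values shown sits, means the true size of that step is not known, only its floor.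

Compound 3, `Cc1ccc(-c2ccc(CSc3nnc(-c4ccc5c(c4)OCCO5)o3)cc2)nc1`, is not yet measured. Its change from compound 2 is 5-methylpyridin-2-yl in place of 6-fluoropyridin-3-yl on an aromatic carbon. This returns a methyl-bearing pyridine in place of the fluoropyridine, reversing the substituent change seen in the measured step, though with the nitrogen placed differently within the ring. On that basis a drop in solubility toward the value of compound 1 is expected, likely large. The step from compound 2 to compound 3 is estimated at an 8.5-fold lower number from compound 2 to compound 3 (0.93 log units; beyond the scatter). For compound 3 the expected value in this assay is 2000 nM, with a range from 500 nM to 8000 nM.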

Compound 3, solubility: 1000 nM
The estimate for compound 3 lay 2.0-fold (0.30 log units) above the measured number; low and high end bracket the measured number.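

Putting 5-methylpyridin-2-yl in place of 6-fluoropyridin-3-yl, on an aromatic carbon para to a large group, gives a 17-fold lower number from compound 2 to compound 3 (1.23 log units; beyond the scatter) in this assay. The earlier step showed a low reading for one methyl-bearing pyridine only. Compound 3 now shows that a second methyl-bearing pyridine, with its nitrogen placed differently in the ring, also reads well under compound 2, so compound 2 stands apart from both of the others shown. Between the two methyl-bearing pyridines the data give only a number no lower from compound 1 to compound 3 (the limit leaves the size open), because one end of that step is a limit and not a number: the limit of < 1000 nM in this assay, at which 1 of the 3 values shown sits.

Compound 2 and compound 3 differ in the substituent and in the place of the ring nitrogen at once, so the compounds shown leave open how much of the step belongs to each, and a 5-fluoropyridin-2-yl group would separate the two. They also leave open how a methoxy group, an amine or a carboxylic acid would read in place of the fluoro of compound 2.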